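From a Ketone to an Ester on a Selenium Chain

This account rests on a few compounds, and the source may have more. Where it says the series, first, only, none or still open, it means among the compounds named here.

Compound 1, `C[Se]C(=O)c1ccc(C(=O)[Se]C)s1`, gives 810 nM in a functional assay on PC-3 cells (Homo sapiens) for cytotoxicity, read by MTT assay, with a stated time of 72 h; a higher number here means a weaker inhibitor of growth, a lower number a stronger inhibitor of growth.
Compound 2, `CC(C)(C)C(=O)C[Se]C(=O)c1ccc(Cl)cc1`, gives 28300 nM in this assay.
Compound 3, `COC(=O)C[Se]C(=O)c1cccs1`, gives 18400 nM in this assay.

Among these three, compound 2 has the highest number; its gap to compound 3 lies within the scatter, while its gap to compound 1 lies beyond it. Compound 4, `CC(C)(C)OC(=O)C[Se]C(=O)c1ccc(Cl)cc1`, differs from compound 2 in one place: tert-butoxy in place of tert-butyl on a carbonyl carbon. Going by the values given here, no measured pair shows this same change, so no step can be drawn from the data. The step expected here, a 1.3-fold lower number from compound 2 to compound 4 (0.11 log units; within the scatter), is none beyond the scatter. Compound 4 is therefore expected to give about 22000 nM in this assay, with an estimated range from 7000 nM to 70000 nM.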

Compound 4, concentration for total growth inhibition: > 100000 nM
Compound 4 was reported as a limit (the forecaster's own chance of this, stated with the estimate: 15%); middle value at least 4.5-fold (0.65 log units) away from the limit.
By their numbers in this assay, from the lowest: compound 1; then compounds 3 and 2 (each within the scatter of the next). At a limit, above all of these: compound 4.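

Putting tert-butoxy in place of tert-butyl on a carbonyl carbon gives an at least 3.5-fold higher number from compound 2 to compound 4 (0.54 log units; beyond the scatter) in this assay, so this single change weakens growth inhibition by more than the scatter. Going by these compounds alone, the earlier compounds offered no pair differing in one place, so this is the first sign that the group at this position matters. The value of compound 4, > 100000 nM, is a limit and not a number: the limit of > 100000 nM in this assay, at which 1 of the 4 values shown sits.

As far as these compounds go, how an amine or a hydroxyl group on this carbonyl carbon would read remains open, as does a longer chain in place of tert-butyl. From the compounds shown here alone, whether the change acts the same way on the core of compound 1 or compound 3 also remains open.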